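From compound 3 to compound 4: a change on sulfur

The compounds below may be only part of what the source reports. "The series", "measured", "known", "first", "only" and "open" are said of these compounds alone.

In a functional assay on MGC-803 cells (Homo sapiens) for antiproliferative activity, read by MTT assay, with a stated time of 48 h (a lower number here means a stronger inhibitor, a higher number a weaker inhibitor), compound 3 (`COc1ccc2nc(SCC(=O)N(Cc3ccc(OC)c(O)c3)c3cc(OC)c(OC)c(OC)c3)sc2c1`) gives 71 nM, the lowest of the three numbers measured. Compound 1 (`COc1ccc(CN(C(=O)CSc2nc3ccccc3s2)c2cc(OC)c(OC)c(OC)c2)cc1N=[N+]=[N-]`) gives 187 nM, and compound 2 (`COc1cc(CN(C(=O)CSc2nc3ccccc3s2)c2cc(OC)c(OC)c(OC)c2)cc(OC)c1OC`) gives 45700 nM. Compound 4 (`COc1ccc(CN(C(=O)CSc2nc3cc(Br)ccc3s2)c2cc(OC)c(OC)c(OC)c2)cc1O`) departs from compound 3 through (a group of 10 heavy atoms (7 carbon, 1 nitrogen, 1 sulfur, 1 bromine; one five-membered aromatic ring with 2 hetero atoms, one six-membered aromatic ring of carbon only) in place of a group of 11 heavy atoms (8 carbon, 1 nitrogen, 1 oxygen, 1 sulfur; one five-membered aromatic ring with 2 hetero atoms, one six-membered aromatic ring of carbon only), on a sulfur). Among the compounds with values here, the only measured step, a 240-fold higher number from compound 1 to compound 2 (2.39 log units; beyond the scatter), concerns a different group, on a saturated chain carbon bound to an amide-type nitrogen. Within the data shown here, it shows that this assay can respond strongly to a substitution, but no measured step touches the group on sulfur. A small rise is therefore expected, with wide uncertainty, and the estimated change is a 2.3-fold higher number from compound 3 to compound 4 (0.35 log units; beyond the scatter). For compound 4 the expected value is 160 nM, with an estimated range of 35 nM to 750 nM.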

Compound 4, half-maximal inhibitory concentration: 372 nM
Beside the measured number, compound 4's estimate is 2.3-fold (0.37 log units) below it; measured number inside the range.
By their numbers in this assay, from the lowest: compound 3; then compounds 1 and 4 (each within the scatter of the next); then compound 2.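

In this assay, the group on sulfur proves to be a position that matters: exchanging the 6-methoxy-1,3-benzothiazol-2-yl group for the bromine-bearing group gives a 5.2-fold higher number from compound 3 to compound 4 (0.72 log units; beyond the scatter). Within the data shown here, the earlier step concerned another group, so this is the first measured response at this place, and it shows that this exchange weakens the compound without abolishing its activity. Nothing measured here bears on why the number rises. This single pair cannot separate the loss of the methoxy group from the gain of bromine. On these data alone, how an amine or a chlorine atom would fare in the bromine's place remains open.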